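Amino in place of butoxy on the shared core

The compounds below may be only part of what the source reports. "The series", "measured", "known", "first", "only" and "open" are said of these compounds alone.

Of the compounds shown here, three built on one shared core have been measured in an ADME assay on cells (Fibroblast, Homo sapiens) for inhibition, read by MTT assay, with a stated time of 24 h; a lower number here means a stronger inhibitor, a higher number a weaker inhibitor. For the measured compounds named here, compound 1 `O=C(N/N=C/c1ccc2c(c1)no[n+]2[O-])c1ccc(Cl)c(Cl)c1` gives 65000 nM, the only number among the three. Compound 2 `CCCCOc1ccc(C(=O)N/N=C/c2ccc3c(c2)no[n+]3[O-])cc1` reaches only the limit of the assay, > 200000 nM. Compound 3 `O=C(N/N=C/c1ccc2c(c1)no[n+]2[O-])c1ccc(I)cc1` likewise sits at the limit of the assay, > 200000 nM. Going by the values given here, the one structural change that has been measured, iodo in place of butoxy on an aromatic carbon, is a step that the two limits leave unreadable from compound 2 to compound 3; it shows neither a size nor a direction, because of the limit of > 200000 nM in this assay, at which 2 of the 3 values shown sit, both of its ends are limits rather than numbers.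

Compound 4 `Nc1ccc(C(=O)N/N=C/c2ccc3c(c2)no[n+]3[O-])cc1` has not yet been measured. Against compound 2 the difference is: amino in place of butoxy on an aromatic carbon. Among the compounds with values here, compound 2 therefore stands at the limit of this assay, with no measured number to build on, and the single measured step gives no size that could be carried over. Within the data shown here, no other step bears on this change. The expected step of an at least 1.1-fold lower number from compound 2 to compound 4 (0.04 log units; that floor lies within the scatter) is estimated as none beyond the scatter, a guess anchored on compound 2 alone. For compound 4 the expected value is 180000 nM, with a range from 70000 nM to 450000 nM. The assay is expected, more likely than not, to report only a limit again.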

Compound 4, half-maximal inhibitory concentration: > 200000 nM
Compound 4 gave a limit, no number; the forecaster's own chance of this, stated with the estimate: 55%; at least 1.1-fold (0.04 log units) between middle value and limit.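

Compound 4 gives only a limit, as do compound 2 and compound 3, so no step among these three compounds can be read, because none of them has a number to compare: the limit of > 200000 nM in this assay, at which 3 of the 4 values shown sit.

The compounds shown leave open whether amino, butoxy and iodo differ from one another in this assay at all.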